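The source may hold more compounds than are shown below. What is called first, only, known or untested is meant among the compounds shown, and "the series" means these compounds.

In a functional assay (muscle tissue) with Cavia porcellus as the target (a higher number here means that more compound is needed for the effect, a lower number that less compound is needed), three compounds built on one shared core have been measured so far. Compound 1 `COC(=O)C1=C(C)N=C(C)/C(=C(\O)OC)C1c1ccc(Cl)cc1` gives 8130 nM, compound 2 `COC(=O)C1=C(C)N=C(C)/C(=C(\O)OC)C1c1ccc(I)cc1` gives 22900 nM, and compound 3 `COC(=O)C1=C(C)N=C(C)/C(=C(\O)OC)C1c1cccc(OC(=O)c2ccccc2)c1` gives 6310 nM. Compound 3 thus stands within the scatter of compound 1 and clearly under compound 2.

Compound 4 `COC(=O)C1=C(C)N=C(C)/C(=C(\O)OC)C1c1cccc(F)c1` differs from compound 3 by fluoro in place of benzoyloxy on an aromatic carbon, meta to a large group (fluoro in place of benzoyloxy on an aromatic carbon). Going by the values given here, only one measured step bears on this change, and only loosely: a 2.8-fold higher number from compound 1 to compound 2 (0.45 log units; beyond the scatter), a modest step with iodo in place of chloro. Among the compounds with values here, no measured step removes benzoyloxy. Still, compound 1 at 8130 nM and compound 3 at 6310 nM lie within the scatter of each other despite their very different substituents. A shift beyond the scatter in this assay is therefore not expected, and no direction is firmly favoured. The expected step is a 1.3-fold higher number from compound 3 to compound 4 (0.10 log units; within the scatter). For compound 4 the estimated value is 8000 nM, with an expected range of 2500 nM to 25000 nM.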

Compound 4, half-maximal effective concentration: 20.9 nM
Compound 4: middle estimate off by 380-fold (2.58 log units), on the high side; the measured number lies below the stated range.
By their numbers in this assay, from the lowest: compound 4; then compounds 3 and 1 (each within the scatter of the next); then compound 2.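

In this assay, going by these compounds alone, the substituent on the aromatic ring turns out to be able to move the number far more than the earlier compounds suggested: fluoro in place of benzoyloxy on the same aromatic carbon gives a 300-fold lower number from compound 3 to compound 4 (2.48 log units; beyond the scatter). The other two steps to 3-fluorophenyl, a 390-fold lower number from compound 1 to compound 4 (2.59 log units; beyond the scatter) and a 1100-fold lower number from compound 2 to compound 4 (3.04 log units; beyond the scatter), are also large, whereas the step from chloro to iodo, a 2.8-fold higher number from compound 1 to compound 2 (0.45 log units; beyond the scatter), is only modest. The closeness of compound 1 and compound 3 therefore did not mean that this part of the molecule is indifferent to change.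

Nothing available here accounts for the size of this drop. As far as these compounds go, it remains open whether the low number follows fluoro itself or its place on the ring, and whether a nitro group or a methoxy group in that place would give a similarly low number.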